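A few compounds are considered here, and "the series" means these few. Any claim that something is new, unique, unknown or untested is made for them only; others in the source may bear on it.

Compound 1 `Cc1cc(C)nc(NS(=O)(=O)c2ccc(Nc3nncc4ccccc34)cc2)n1`: 4.9 nM
Compound 2 `O=S(=O)(Nc1ccccn1)c1ccc(Nc2nncc3ccccc23)cc1`: 34 nM

Within the data shown here, in a functional assay on K562 cells (Homo sapiens) for antiproliferative activity, read by sulforhodamine B assay, with a stated time of 72 h (on this read-out lower numbers stand for stronger inhibition and higher numbers for weaker inhibition), compound 2 gives 34 nM, the higher of the two numbers so far. Compound 3 `Cc1cc(NS(=O)(=O)c2ccc(Nc3nncc4ccccc34)cc2)no1` keeps the shared core and changes one group: 5-methyl-1,2-oxazol-3-yl in place of pyridin-2-yl on a sulfonamide nitrogen. In words, 5-methyl-1,2-oxazol-3-yl stands in place of pyridin-2-yl on a sulfonamide nitrogen. Among the measured compounds shown here, one measured step bears on this place: a 6.9-fold higher number from compound 1 to compound 2 (0.84 log units; beyond the scatter). It shows that this position can matter, but gives no direction for the new group, so no clear step beyond the scatter is expected. The expected change is a 1.4-fold lower number from compound 2 to compound 3 (0.13 log units; within the scatter). For compound 3 the estimated value is 25 nM, ranging from 6 nM to 100 nM.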

Compound 3, half-maximal inhibitory concentration: 23 nM
Beside the measured number, compound 3's estimate is 1.1-fold (0.04 log units) above it; measured number inside the range.
By their numbers in this assay, from the lowest: compound 1; then compounds 3 and 2 (each within the scatter of the next).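

In this assay, a five-membered ring can stand on the sulfonamide nitrogen in place of a six-membered one: the change to 5-methyl-1,2-oxazol-3-yl gives a 1.5-fold lower number from compound 2 to compound 3 (0.17 log units; within the scatter), so the two groups cannot be told apart here. Compound 1, with its 4,6-dimethylpyrimidin-2-yl group, now has the lower number against both other compounds, with a 4.7-fold higher number from compound 1 to compound 3 (0.67 log units; beyond the scatter) alongside a 6.9-fold higher number from compound 1 to compound 2 (0.84 log units; beyond the scatter). Nothing available here explains this difference. Still open, on these data alone, is whether a pyrimidin-2-yl group without its two methyl groups would match compound 1, or whether a simple phenyl ring would serve at this position.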